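A Thiophene Ring Takes the Place of the Benzyl Tail

The source may report more compounds than this note shows. Statements on the series, on what has been measured and on what is new or still open speak of the compounds shown alone.

Compound 1 `C=C(Br)C(=O)Nc1cccc(-c2cn3nc(Cc4cccc(OC)c4)sc3n2)c1` is the most potent of the two numbers at hand: in a functional assay on CCRF-CEM cells (Homo sapiens) for inhibition, read by cell counting, with a stated time of 3 days (a lower number here means a stronger inhibitor, a higher number a weaker inhibitor), compound 1 gives 3100 nM. Its nearest neighbour is compound 3 `COc1cccc(Cc2nn3cc(-c4cccc(N)c4)nc3s2)c1`, which in this assay gives 40000 nM; the step of a 13-fold higher number from compound 1 to compound 3 (1.11 log units; beyond the scatter) comes from putting a hydrogen in place of the (1-bromoethenyl)carbonyl group on the ring nitrogen. Compound 2 `COc1ccc(Cc2nn3cc(-c4cccc(N)c4)nc3s2)cc1` reports only a limit in this assay, namely >= 250000 nM, which is the limit of >= 250000 nM in this assay, at which 1 of the 3 values shown sits. Moving the methoxy group gives the step of an at least 6.2-fold lower number from compound 2 to compound 3 (0.79 log units; beyond the scatter).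

Compound 4 `C=C(Br)C(=O)Nc1cccc(-c2cn3nc(-c4cccs4)sc3n2)c1` differs from compound 1 by thiophen-2-yl in place of 3-methoxybenzyl on an aromatic carbon. Neither measured step alters this position directly: one removes the bromoacrylamide, the other only moves a methoxy group on the benzyl. The second step does show that the benzyl region matters, and the full exchange of that group for a thiophene is a larger change, so the outcome could go either way. For compound 4 the step of a 1.3-fold higher number from compound 1 to compound 4 (0.11 log units; within the scatter) is expected to stay modest, with wide uncertainty. Compound 4 is therefore estimated at 4000 nM, within 1000 nM to 16000 nM.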

Compound 4, half-maximal inhibitory concentration: 410 nM
Beside the measured number, compound 4's estimate is 9.8-fold (0.99 log units) above it, and the stated range ends above it.
By their numbers in this assay, from the lowest: compound 4; then compound 1; then compound 3. At a limit, above all of these: compound 2.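

Exchanging the 3-methoxybenzyl for thiophen-2-yl in this assay gives a 7.6-fold lower number from compound 1 to compound 4 (0.88 log units; beyond the scatter) while the (1-bromoethenyl)carbonyl group stays in place. The earlier comparison of compound 2 and compound 3 only moved a methoxy group around the benzyl, whereas this result shows that the whole benzyl can leave this aromatic carbon, next to the ring nitrogen and the ring sulfur, without any loss, and with a lower number. The group that enters also has fewer heavy atoms, 5 against 9, so at this position in these two compounds the larger group is not needed, and the data at hand give no measured reason for the drop.

Going by these compounds, this single exchange changes several things at once: the ring, the saturated chain carbon and the methoxy group all differ, so the share of each stays unknown. A plain phenyl ring, a furan-2-yl ring or a thiophen-2-ylmethyl group at this position would separate those parts, and the free aromatic amine that matches compound 4 would show whether the bromo-bearing group adds as much here as it does on the benzyl compounds.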